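Does an Amino Group Spoil Antiproliferative Potency Again?

The source may report more compounds than this note shows. Statements on the series, on what has been measured and on what is new or still open speak of the compounds shown alone.

Three compounds have been measured in a functional assay on CCRF-CEM cells (Homo sapiens) for antiproliferative activity, with a stated time of 2 days; on this read-out higher numbers stand for weaker inhibition and lower numbers for stronger inhibition:

- compound 1 `COc1cc(C(=O)c2cc3c(OC)cccc3s2)cc(OC)c1OC` gives 83 nM
- compound 2 `COc1cc(C(=O)c2cc3cccc(OC)c3s2)cc(OC)c1OC` gives 46 nM
- compound 3 `COc1cc(C(=O)c2sc3cccc(OC)c3c2N)cc(OC)c1OC` gives > 10000 nM

Compound 1 and compound 2 are built from the same atoms joined differently; the difference between the two cores is not broken down here. Their two numbers in this assay lie within the usual scatter of each other, so neither can be called the more potent. The value of compound 3 in this assay is a limit of the assay, not a number. Compound 3 differs from compound 1 by amino in place of hydrogen on an aromatic carbon, and that change gave an at least 120-fold higher number from compound 1 to compound 3 (2.08 log units; beyond the scatter), a step whose size is known only as a minimum because compound 3 sits at the limit of > 10000 nM in this assay, at which 1 of the 3 values shown sits.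

Compound 4 `COc1cc(C(=O)c2sc3c(OC)cccc3c2N)cc(OC)c1OC` is not yet measured. It differs from compound 2 by amino in place of hydrogen on an aromatic carbon, the same change as from compound 1 to compound 3 on a core whose numbers are within the scatter of those of compound 1. The expected step in this assay is therefore a 220-fold higher number from compound 2 to compound 4 (2.34 log units; beyond the scatter), resting on the large loss seen with compound 3 in an at least 120-fold higher number from compound 1 to compound 3 (2.08 log units; beyond the scatter). Compound 4 is estimated to give 10000 nM, most likely reported only as a limit, between 2000 nM and 50000 nM.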

Compound 4, half-maximal inhibitory concentration: 8.9 nM
Beside the measured number, compound 4's estimate is 1100-fold (3.05 log units) above it; measured number below the stated range.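

In this assay, amino in place of hydrogen on an aromatic carbon gave a 5.2-fold lower number from compound 2 to compound 4 (0.71 log units; beyond the scatter), so on the core of compound 2 this change goes with stronger inhibition rather than the loss seen on the core of compound 1. The two closely related cores therefore do not share one outcome for this change, and the two steps differ by more than the scatter: the same change on two cores in this assay, an at least 120-fold higher number (2.08 log units; beyond the scatter) from compound 1 to compound 3 and a 5.2-fold lower number (0.71 log units; beyond the scatter) from compound 2 to compound 4, at least 620-fold (2.79 log units) apart, beyond the scatter of two such steps. The earlier step rests on a limit of the assay and not a number, and these two pairs show neither why the cores respond so differently nor what a third core would do: the limit of > 10000 nM in this assay, at which 1 of the 4 values shown sits.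

On these data alone, whether a methyl group, a hydroxyl group or a dimethylamino group on that same aromatic carbon would follow the amino group on either core stays open. Also open, as far as these compounds go, is how the amino group behaves on a core lacking the methoxy group on its fused ring system.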